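Methoxy on the anilino ring of a bromophenylsulfonyl quinoxaline

The source may hold more compounds than are shown below. What is called first, only, known or untested is meant among the compounds shown, and "the series" means these compounds.

Of the compounds shown here, three sharing one core have been tested in a functional assay on HL-60 cells (Homo sapiens) for cytotoxicity, read by MTT assay, with a stated time of 72 h; a lower number here means a stronger inhibitor, a higher number a weaker inhibitor. Compound 1 `O=S(=O)(c1ccccc1)c1nc2ccccc2nc1Nc1ccc(F)cc1` gives 1010 nM. Compound 2 `COc1ccc(S(=O)(=O)c2nc3ccccc3nc2Nc2ccc(F)cc2)cc1`, which carries a methoxy in place of hydrogen on an aromatic carbon, gives 610 nM, a step of a 1.7-fold lower number from compound 1 to compound 2 (0.22 log units; within the scatter). Compound 3 `O=S(=O)(c1ccc(Br)cc1)c1nc2ccccc2nc1Nc1ccccc1` gives 130 nM, the lowest of the three numbers; the difference between its core and that of compound 1 is not broken down here.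

Compound 4 `COc1ccc(Nc2nc3ccccc3nc2S(=O)(=O)c2ccc(Br)cc2)cc1` has not yet been measured. It differs from compound 3 by the same change, methoxy in place of hydrogen on an aromatic carbon, though here the change, cut one bond further out, reads anilino to (4-methoxyphenyl)amino, whereas in compound 2 it reads phenyl to 4-methoxyphenyl. The one earlier example of this change, from compound 1 to compound 2, moved the number only within the scatter, so the author expects compound 4 to land close to compound 3, with a step of about a 1.4-fold lower number from compound 3 to compound 4 (0.14 log units; within the scatter) in this assay, leaning slightly toward a lower number because that is the direction shown by a 1.7-fold lower number from compound 1 to compound 2 (0.22 log units; within the scatter). The estimate for compound 4 is therefore 95 nM, with a range from 35 nM to 260 nM.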

Compound 4, half-maximal inhibitory concentration: 1190 nM
For compound 4 the middle estimate is 13-fold (1.10 log units) below the measured one, outside the stated range (above it).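

In this assay the methoxy in place of hydrogen gives a 9.2-fold higher number from compound 3 to compound 4 (0.96 log units; beyond the scatter), which takes compound 4 away from the low number of compound 3 rather than further down. Set beside the earlier example, the change does not carry over as one constant step between these two cores: the same change on two cores in this assay, a 1.7-fold lower number (0.22 log units; within the scatter) from compound 1 to compound 2 and a 9.2-fold higher number (0.96 log units; beyond the scatter) from compound 3 to compound 4, 15-fold (1.18 log units) apart, beyond the scatter of two such steps. This shows that, in this series, a step measured on one core cannot simply be transferred to another, but with one pair on each side it does not show what sets the two steps apart, since the change reads phenyl to 4-methoxyphenyl in one pair and anilino to (4-methoxyphenyl)amino in the other, and the two pairs also differ elsewhere in their cores, so the place of the methoxy and the rest of the core cannot be separated.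

The compounds shown leave open whether the higher number belongs to methoxy itself or would also follow from another group in the same place on the anilino ring of compound 3, such as a hydroxyl or a dimethylamino group. They also leave open what a methoxy on the other aromatic ring would do with the anilino ring left unsubstituted.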